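The compounds below may be only part of what the source reports. "The series", "measured", "known", "first", "only" and "open" are said of these compounds alone.

Measured in a functional assay on A549 cells (Homo sapiens) for antiproliferative activity, read by MTT assay, with a stated time of 72 h; on this read-out higher numbers stand for weaker inhibition and lower numbers for stronger inhibition:
- Compound 1 `COc1ccccc1-c1ccc2ncn(-c3cc(OC)c(OC)c(OC)c3)c2c1`: 4320 nM
- Compound 2 `COc1cc(-n2cnc3ccc(-c4cccc([N+](=O)[O-])c4)cc32)cc(OC)c1OC`: 5410 nM

Among the compounds with values here, compound 2, at 5410 nM, lies within the scatter of compound 1, at 4320 nM, and these are the only two numbers available. Compound 3 `COc1cc(-n2cnc3ccc(-c4ccc(C)cc4)cc32)cc(OC)c1OC` keeps the core of compound 2 and carries 4-methylphenyl in place of 3-nitrophenyl on an aromatic carbon. Within the data shown here, one measured step bears on this change, since it exchanges a group at the same place: a 1.3-fold higher number from compound 1 to compound 2 (0.10 log units; within the scatter), which stays within the scatter. Among the measured compounds shown here, no measured compound carries 4-methylphenyl, so this single step is thin support. On that evidence, no change beyond the scatter is expected in this assay, in either direction. The expected step is a 1.2-fold lower number from compound 2 to compound 3 (0.08 log units; within the scatter). Compound 3 is estimated at 4500 nM, with an expected range of 1800 nM to 11000 nM.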

Compound 3, half-maximal inhibitory concentration: 1940 nM
For compound 3 the middle estimate is 2.3-fold (0.37 log units) above the measured one; the range from low to high includes it.
By their numbers in this assay, from the lowest: compound 3; then compounds 1 and 2 (each within the scatter of the next).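

In this assay, the earlier pair left it unclear whether exchanging the aryl group on this aromatic carbon could move the number beyond the scatter, and compound 3 shows that it can. 4-Methylphenyl in place of 3-nitrophenyl gives a 2.8-fold lower number from compound 2 to compound 3 (0.45 log units; beyond the scatter), and 4-methylphenyl in place of 2-methoxyphenyl gives a 2.2-fold lower number from compound 1 to compound 3 (0.35 log units; beyond the scatter), so both modest steps run the same way, and 4-methylphenyl stands apart from two groups that lie within the scatter of each other. Nothing measured here accounts for this difference.

Going by these compounds, what remains open is whether the lower number depends on the methyl group itself or would also appear with an unsubstituted phenyl ring. On these data alone, it is also open how a phenyl ring carrying an amine, a carboxylic acid or a longer alkyl chain at this place would compare.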